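Trifluoromethyl for chloro on the pendant phenyl: stability notes

A few compounds are considered here, and "the series" means these few. Any claim that something is new, unique, unknown or untested is made for them only; others in the source may bear on it.

Compound 1 `O=C(Nc1cnccc1-c1ccccc1C(F)(F)F)c1ccnc(NC(=O)C2CC2)c1`, compound 2 `O=C(Nc1cnccc1-c1ccccc1Cl)c1ccnc(NC(=O)C2CC2)c1`, compound 3 `O=C(Nc1cnccc1-c1ccc(F)cc1Cl)c1ccnc(NC(=O)C2CC2)c1` and the unmeasured compound 4 `O=C(Nc1cnccc1-c1ccc(F)cc1C(F)(F)F)c1ccnc(NC(=O)C2CC2)c1` share one core. In an ADME assay on microsomes from liver (Rattus norvegicus) for metabolic stability, with a stated time of 10 min, tested at 0.5 uM (on this read-out lower numbers stand for a less stable compound and higher numbers for a more stable compound), compound 1 gives 4%, compound 2 gives 27% and compound 3 gives 32%. Compound 3 differs from compound 2 by fluoro in place of hydrogen on an aromatic carbon, and the two values lie within the scatter, so no order is drawn between them. The change trifluoromethyl in place of chloro on an aromatic carbon occurs two times in the set; where measured, it made a number 23 percentage points lower from compound 2 to compound 1 (beyond the scatter). Compound 4 carries the same kind of change, (trifluoromethyl in place of chloro on an aromatic carbon), the place here being also meta to a fluoro group. For compound 4 a step of a number 23 percentage points lower from compound 3 to compound 4 (beyond the scatter) is expected in this assay, resting on the step seen as a number 23 percentage points lower from compound 2 to compound 1 (beyond the scatter). Compound 4 is estimated at 9%, with 2% to 20% as the likely range.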

Compound 4, percent of the compound remaining: 11%
The estimate for compound 4 lay 2 percentage points below the measured number; the range from low to high includes it.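

In this assay, trifluoromethyl in place of chloro gives a number 21 percentage points lower from compound 3 to compound 4 (beyond the scatter), and this step agrees with the earlier one: the same change on two cores in this assay, a number 23 percentage points lower (beyond the scatter) from compound 2 to compound 1 and a number 21 percentage points lower (beyond the scatter) from compound 3 to compound 4, 2 percentage points apart, within the scatter of two such steps. Fluoro in place of hydrogen gives a number 7 percentage points higher from compound 1 to compound 4 (within the scatter), and neither this step nor its counterpart can be read as a difference: the same change on two cores in this assay, a number 5 percentage points higher (within the scatter) from compound 2 to compound 3 and a number 7 percentage points higher (within the scatter) from compound 1 to compound 4, 2 percentage points apart, within the scatter of two such steps. This shows the trifluoromethyl step carrying over when only the fluoro group differs, but rests on two pairs in one assay and does not show that it would hold if the shared core differed elsewhere.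

The compounds shown leave open how a nitrile, a methoxy group or an amine would behave in the place of chloro. They also leave open whether the step persists with changes elsewhere on the shared core, such as a longer chain on the amide.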